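This account rests on a few compounds, and the source may have more. Where it says the series, first, only, none or still open, it means among the compounds named here.

Of the compounds shown here, two have numbers so far in a functional assay on HEK293 cells for agonist activity at Vasopressin V2 receptor (Homo sapiens), read by a luciferase reporter and cAMP accumulation; a higher number here means that more compound is needed for the effect, a lower number that less compound is needed. Compound 1 `Cc1cc(C(=O)N2CCCCc3ccccc32)ccc1CNC(=O)NCC(=O)O` gives 180 nM in this assay, which is the highest of the two numbers. Among the compounds with values here, compound 2 `Cc1cc(C(=O)N2CCCCc3ccccc32)ccc1CNC(=O)N1C[C@H](O)C[C@H]1C(=O)N(C)C` gives 2.3 nM in this assay; the single step between them is a 78-fold lower number from compound 1 to compound 2 (1.89 log units; beyond the scatter), with 2-(dimethylcarbamoyl)-4-hydroxypyrrolidin-1-yl in place of (carboxymethyl)amino on a carbonyl carbon. Compound 3 `CO[C@@H]1C[C@@H](C(=O)N(C)C)N(C(=O)NCc2ccc(C(=O)N3CCCCc4ccccc43)cc2C)C1` has not yet been measured. Its difference from compound 1 is counted as 2-(dimethylcarbamoyl)-4-methoxypyrrolidin-1-yl in place of (carboxymethyl)amino on a carbonyl carbon. Within the data shown here, the change sits at the same carbonyl carbon as the measured step, and the entering group differs from the one that enters in compound 2 only in methoxy for hydroxy within the group's name. Among the measured compounds shown here, the one measured step that bears on this change is therefore the step from compound 1 to compound 2, and it was large. The step expected in this assay is a 60-fold lower number from compound 1 to compound 3 (1.78 log units; beyond the scatter), a large drop of about the same order as that measured one, well beyond the scatter. Compound 3 is estimated at 3 nM in this assay, with a range from 1 nM to 12 nM.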

Compound 3, half-maximal effective concentration: 4.7 nM
Estimate against measurement, compound 3: 1.6-fold (0.19 log units) below; low and high end bracket the measured number.
By their numbers in this assay, from the lowest: compound 2; then compound 3; then compound 1.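

In this assay, the large drop at this carbonyl carbon persists when methyl replaces the hydrogen on the oxygen (a 38-fold lower number from compound 1 to compound 3 (1.58 log units; beyond the scatter)), so the free hydroxy of compound 2 is not required for most of it. Within the data shown here, the oxygen substituent still registers, though only as a modest step (a 2.0-fold higher number from compound 2 to compound 3 (0.31 log units; beyond the scatter)), and this is the first reading of a change within the entering group rather than an exchange of the whole group. Among the compounds shown, the two groups with the dimethylcarbamoyl pyrrolidine, whether carrying hydroxy or methoxy, both lie far below compound 1, while nothing available accounts for either step.

Each pyrrolidine is compared with compound 1 only as a whole group, so the shares of the ring, the dimethylcarbamoyl and the loss of the carboxylic acid in the large drop remain unseparated. Also open, from the compounds shown here alone, is how far the oxygen substituent tolerates change, for example ethoxy, a longer ether chain or an amine in place of methoxy, and whether the two defined stereocentres matter.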